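This account rests on a few compounds, and the source may have more. Where it says the series, first, only, none or still open, it means among the compounds named here.

For the measured compounds named here, compound 2 `COc1cc2c(cc1OC)C(CC(=O)NC1CCCC1)CC2` stands highest of the two compounds measured so far in a functional assay on the whole organism (strain Wistar) for inhibition, with Rattus norvegicus as the target, read by paw edema, with stated times of 60 min and 24 h, at a dose of 100 mg/kg by the oral route (a higher number here means more inhibition at the dose given (going by the name of the read-out), a lower number less inhibition), where compound 2 gives 46.7%; compound 1 `COc1cc2c(cc1OC)C(CC(=O)NC(C)C)CC2` gives 30%. That one earlier step, a number 16.7 percentage points higher from compound 1 to compound 2 (beyond the scatter), is the only one that bears on the next change, in which a ring in the same place grows by one carbon: cyclohexyl in place of cyclopentyl on an amide-type nitrogen. Compound 3 `COc1cc2c(cc1OC)C(CC(=O)NC1CCCCC1)CC2` is therefore expected to sit near or a little above compound 2, with a step of about a number 5.3 percentage points higher from compound 2 to compound 3 (within the scatter). The expected value for compound 3 in this assay is 52%, within a range from 35% to 68%.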

Compound 3, a percentage reported as inhibition, in the whole organism at one dose (the size of the read-out at that dose, not a potency): 53.3%
Compound 3: middle estimate off by 1.3 percentage points, on the low side, within the range that was stated.
By their numbers in this assay, from the lowest: compound 1; then compounds 2 and 3 (each within the scatter of the next).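

In this assay the change from cyclopentyl to cyclohexyl on the amide-type nitrogen gives a number 6.6 percentage points higher from compound 2 to compound 3 (within the scatter) and so does not separate these two rings. Cyclohexyl in place of isopropyl gives a number 23.3 percentage points higher from compound 1 to compound 3 (beyond the scatter) and so shows that the gap from isopropyl seen with cyclopentyl also holds for the six-membered ring. Nothing available explains these numbers. Still open, as far as these compounds go, is how a phenyl or benzyl group or a straight butyl chain would read on the same nitrogen. Also open, from the compounds shown here alone, is what a methyl group in place of the amide hydrogen would do.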